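The compounds below may be only part of what the source reports. "The series", "measured", "known", "first", "only" and "open" are said of these compounds alone.

Measured in a functional assay on MCF7 cells (Homo sapiens) for inhibition, read by CCK-8 assay, with a stated time of 48 h (a lower number here means a stronger inhibitor, a higher number a weaker inhibitor), so far:
Compound 1 `COc1cc(-c2ccnc3cc(-c4ccc(C)c(C)c4)nn23)cc(OC)c1OC` gives 26 nM
Compound 2 `COc1cc(-c2ccnc3cc(-c4cccc(C#N)c4)nn23)cc(OC)c1OC` gives > 10000 nM as a limit
Compound 3 `COc1cc(-c2ccnc3cc(-c4ccc5c(ccn5C)c4)nn23)cc(OC)c1OC` gives 3 nM

Compound 2 stands at the limit of > 10000 nM in this assay, at which 1 of the 3 values shown sits, and so has no exact number. Compound 4 `COc1cc(-c2ccnc3cc(-c4cccc(C)c4)nn23)cc(OC)c1OC` differs from it by methyl in place of cyano on an aromatic carbon with methyl in place of cyano on an aromatic carbon. Within the data shown here, two measured steps bear on this, both large: an at least 380-fold higher number from compound 1 to compound 2 (2.58 log units; beyond the scatter) for 3-cyanophenyl in place of 3,4-dimethylphenyl, and an at least 3300-fold lower number from compound 2 to compound 3 (3.52 log units; beyond the scatter) for 1-methyl-1H-indol-5-yl in place of 3-cyanophenyl. On these two steps, a large move to a lower number is expected in this assay on leaving 3-cyanophenyl. The expected size is an at least 83-fold lower number from compound 2 to compound 4 (1.92 log units; beyond the scatter) by this estimate. For compound 4 the estimate is 120 nM with an expected range from 20 nM to 1500 nM in all.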

Compound 4, half-maximal inhibitory concentration: 1080 nM
The estimate for compound 4 lay 9.0-fold (0.95 log units) below the measured number; the range from low to high includes it.
By their numbers in this assay, from the lowest: compound 3; then compound 1; then compound 4. At a limit, above all of these: compound 2.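

In this assay, compound 2 has only a limit, > 10000 nM. Methyl in place of cyano, meta to a large group, gives a measurable number, an at least 9.2-fold lower number from compound 2 to compound 4 (0.96 log units; beyond the scatter). That methyl alone falls well short, though: 3,4-dimethylphenyl reads far lower than 3-methylphenyl, a 42-fold higher number from compound 1 to compound 4 (1.62 log units; beyond the scatter), and 1-methyl-1H-indol-5-yl lower still, a 360-fold higher number from compound 3 to compound 4 (2.56 log units; beyond the scatter).

As far as these compounds go, how a methoxy, a chlorine or an amine on this carbon would compare with methyl in this assay remains open.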